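Distal aryl halide swap in the benzamide: bromo to fluoro

A few compounds are considered here, and "the series" means these few. Any claim that something is new, unique, unknown or untested is made for them only; others in the source may bear on it.

Measured in a functional assay on A-375 cells (Homo sapiens) for inhibition, read by CCK-8 assay, with a stated time of 72 h, tested at 2 uM; on this read-out higher numbers stand for more inhibition of growth at the one concentration tested and lower numbers for less inhibition of growth:
Compound 1 `Cc1ccc(SCc2ccc(/C=C/C(=O)Nc3ccccc3N)cc2)cc1`: 22.9%
Compound 2 `Nc1ccccc1NC(=O)c1ccc(CSc2ccc(Br)cc2)cc1`: 4.35%
Compound 3 `CC(C)(C)c1ccc(SCc2ccc(/C=C/C(=O)Nc3ccccc3N)cc2)cc1`: 38.4%

Compound 2 stands lowest of the three numbers in this assay; compound 1 lies higher by a margin beyond the scatter, and compound 3 higher still. Compound 4 `Nc1ccccc1NC(=O)c1ccc(CSc2ccc(F)cc2)cc1` differs from compound 2 by fluoro in place of bromo on an aromatic carbon. For the measured compounds named here, the only measured step, a number 15.5 percentage points higher from compound 1 to compound 3 (beyond the scatter), sits on the other amide core and swaps alkyl groups, so it does not bear on a halogen exchange. Nothing shown supports a change beyond the scatter, and the step of a number 0.4 percentage points lower from compound 2 to compound 4 (within the scatter) is therefore expected to stay within it. Compound 4 is estimated at 4%, with a range from -8% to 16%.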

Compound 4, percent growth inhibition at one concentration: 19.4%
For compound 4 the middle estimate is 15.4 percentage points below the measured one; measured number above the stated range.
By their numbers in this assay, from the lowest: compound 2; then compounds 4 and 1 (each within the scatter of the next); then compound 3.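

Exchanging the halogen at this ring carbon does move growth inhibition in this assay: fluoro in place of bromo gives a number 15.1 percentage points higher from compound 2 to compound 4 (beyond the scatter), so this position on the core of compound 2 responds to the identity of the halogen. For the compounds shown here, the earlier step covered only an alkyl exchange on a different core, so this is the sole reading of a halogen exchange. No measurement shown accounts for the step.

Chloro or methoxy at this place remains open. So does whether the same exchange gives a comparable step on the core of compound 1.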